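Two Cores, One Swap: Fluoro for Methyl

The source may report more compounds than this note shows. Statements on the series, on what has been measured and on what is new or still open speak of the compounds shown alone.

Compound 1, `C/C(=C\c1ccc(-c2ccc(C)cc2)o1)C(N)=O`, gives 4590 nM in a functional assay on HeLa cells (Homo sapiens) for cytotoxicity, read by CCK-8 assay, with a stated time of 24 h; on this read-out higher numbers stand for weaker inhibition and lower numbers for stronger inhibition.
Compound 2, `C/C(=C\c1ccc(-c2ccc(F)cc2)o1)C(N)=O`, gives 2030 nM in this assay.
Compound 3, `C/C(=C\c1nc(-c2ccc(C)cc2)cs1)C(N)=O`, gives 25000 nM in this assay.

Compound 1 and compound 2 share one core and differ in a single place: fluoro in place of methyl on an aromatic carbon. That change brought a 2.3-fold lower number from compound 1 to compound 2 (0.35 log units; beyond the scatter). Compound 3 carries a different core; the difference between the two cores is not broken down here. In this assay compound 3 stands highest of the three numbers measured, with compound 1 nearest to it and compound 2 furthest, both gaps beyond the scatter.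

Compound 4, `C/C(=C\c1nc(-c2ccc(F)cc2)cs1)C(N)=O`, has not yet been measured in this assay. It stands to compound 3 as compound 2 stands to compound 1: fluoro in place of methyl on an aromatic carbon. The place is described in the same words for both pairs, so this is the same change made twice among these compounds, once on each core.

For the measured compounds named here, the expectation for compound 4 rests on the single measured instance of the change, a 2.3-fold lower number from compound 1 to compound 2 (0.35 log units; beyond the scatter), and on the value of compound 3, 25000 nM. Compound 4 is expected to show a step of a 2.3-fold lower number from compound 3 to compound 4 (0.36 log units; beyond the scatter). The change has been measured only once and only on the other core, so the range for compound 4 is kept wide. Compound 4 is estimated at 11000 nM, with a range from 4500 nM to 28000 nM.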

Compound 4, half-maximal inhibitory concentration: 5400 nM
Beside the measured number, compound 4's estimate is 2.0-fold (0.31 log units) above it; low and high end bracket the measured number.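

On the second core the swap of fluoro for methyl again moved the result in the same direction in this assay, with a 4.6-fold lower number from compound 3 to compound 4 (0.67 log units; beyond the scatter). Set beside the earlier step, the two sizes cannot be told apart, so the change carried over from one core to the other in both direction and size: the same change on two cores in this assay, a 2.3-fold lower number (0.35 log units; beyond the scatter) from compound 1 to compound 2 and a 4.6-fold lower number (0.67 log units; beyond the scatter) from compound 3 to compound 4, 2.0-fold (0.31 log units) apart, within the scatter of two such steps

This rests on one pair on each of two cores, in a single assay, so it shows that the change behaved alike on these two cores but does not show that it would do so on any further core, nor does it explain why the number falls.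

The compounds shown leave open what other groups would do at this same place on the six-membered aromatic ring, such as chloro, methoxy, trifluoromethyl or an amine, and whether any of them would go beyond fluoro on either core. They also leave open how the series would respond if a carboxylic acid or a nitrile stood in place of the amide, and whether the step from methyl to fluoro would keep its size on such compounds.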